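Compound 2 to compound 4: hydroxy replaces dimethylamino

The source may hold more compounds than are shown below. What is called first, only, known or untested is meant among the compounds shown, and "the series" means these compounds.

Of the compounds shown here, three on the shared core have been measured so far in a functional assay, with a stated time of 10 min (a higher number here means a weaker inhibitor, a lower number a stronger inhibitor), and form the whole basis for these notes. There compound 1 `O=c1cc(/C=C/c2cccc(F)c2)[nH]cc1O` gives 6290 nM and compound 3 `COc1ccccc1/C=C/c1cc(=O)c(O)c[nH]1` gives 6740 nM as its reading. Compound 2 `CN(C)c1ccc(/C=C/c2cc(=O)c(O)c[nH]2)cc1` gives 3410 nM in this assay and stands within the scatter of both compound 1 and compound 3, so the three values cannot be ranked. No two of these compounds differ in one place only, so no measured step speaks directly to the next change.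

That change leads to compound 4 `O=c1cc(/C=C/c2ccc(O)cc2)[nH]cc1O` and is set out as hydroxy in place of dimethylamino on an aromatic carbon in the counted comparison. Hydroxy takes the place of dimethylamino on an aromatic carbon of a six-membered aromatic ring of carbon only, para to a large group. Compound 1 at 6290 nM and compound 3 at 6740 nM both lie within the scatter of compound 2 at 3410 nM even though the group on that ring differs in each. No step beyond the scatter is therefore expected, and no direction is favoured. The estimated step of a 1.0-fold higher number from compound 2 to compound 4 (0.01 log units; within the scatter) stays inside that scatter. In this assay the estimate for compound 4 is 3500 nM with an expected range of 1200 nM to 9000 nM until measured.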

Compound 4, half-maximal inhibitory concentration: 1730 nM
The estimate for compound 4 lay 2.0-fold (0.31 log units) above the measured number, and the stated range covers the measured number.
By their numbers in this assay, from the lowest: compounds 4, 2, 1 and 3 (each within the scatter of the next, the first and the last beyond it).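

In this assay, among these compounds, the first step that changes one place only, hydroxy in place of dimethylamino on an aromatic carbon, gives a 2.0-fold lower number from compound 2 to compound 4 (0.29 log units; within the scatter) and so stays within the scatter. At this position, para to a large group, the two groups cannot be told apart in this assay, even though dimethylamino brings 3 heavy atoms and 0 hydrogen-bond donors while hydroxy brings 1 heavy atom and 1 hydrogen-bond donor. No evidence available here bears on what lies behind this result.

Going by these compounds, what a carboxylic acid or a plain amino group on this same aromatic carbon would give remains open, and a step of either kind would show whether this position tolerates more than these two groups. Also open, on these data alone, is whether hydroxy elsewhere on this ring would read as it does here, since only a single-place comparison on the shared core could settle that.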